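Swapping a methylcarbamoyl for a benzyl on the amine nitrogen

The source may hold more compounds than are shown below. What is called first, only, known or untested is meant among the compounds shown, and "the series" means these compounds.

Measured so far:
- compound 1 `CCS(=O)(=O)NC(=O)c1ccc(Nc2nc(NC3(c4ccc(Cl)cc4)CC3)nc(OCC(F)(F)F)n2)cc1`: 28 nm/s
- compound 2 `CNC(=O)NCCS(=O)(=O)NC(=O)c1ccc(Nc2nc(NC3(c4ccc(Cl)cc4)CC3)nc(OCC(F)(F)F)n2)cc1`: 40 nm/s

Within the data shown here, in a physicochemical assay for permeability, using PAMPA, at pH 7.4 (a higher number here means that the compound crosses the layer faster, a lower number that the compound crosses the layer more slowly), compound 2 gives the higher of the two numbers, yet the only measured step, a 1.4-fold higher number from compound 1 to compound 2 (0.15 log units; within the scatter), is within the scatter, so the two compounds cannot be told apart on these data.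

Compound 3 `O=C(NS(=O)(=O)CCNCc1ccccc1)c1ccc(Nc2nc(NC3(c4ccc(Cl)cc4)CC3)nc(OCC(F)(F)F)n2)cc1` is the next compound. It differs from compound 2 in one place: benzyl in place of methylcarbamoyl on an amine nitrogen.

Among the measured compounds shown here, the single measured step, a 1.4-fold higher number from compound 1 to compound 2 (0.15 log units; within the scatter), concerns a different change, the adding of a (methylcarbamoyl)amino group onto a chain carbon, and it was too small to be telling. For the measured compounds named here, no measured pair exchanges a methylcarbamoyl for a benzyl, so there is no direct guide for this step. The number for compound 3 in this assay is therefore expected to lie close to that of compound 2, with a 1.4-fold higher number from compound 2 to compound 3 (0.14 log units; within the scatter) as the estimated step. Compound 3 is estimated at 55 nm/s, in a range from 20 nm/s to 150 nm/s.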

Compound 3, apparent permeability: 49 nm/s
The estimate for compound 3 lay 1.1-fold (0.05 log units) above the measured number; measured number inside the range.
By their numbers in this assay, from the lowest: compounds 1, 2 and 3 (each within the scatter of the next).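

In this assay, exchanging methylcarbamoyl for benzyl on the amine nitrogen gives a 1.2-fold higher number from compound 2 to compound 3 (0.09 log units; within the scatter). This exchange replaces a group of 4 heavy atoms with no ring by one of 7 heavy atoms with a six-membered aromatic ring of carbon only, yet the read-out cannot separate the two compounds. Benzylamino in place of hydrogen on the saturated chain carbon, two bonds along the chain from the sulfonyl sulfur, gives a 1.8-fold higher number from compound 1 to compound 3 (0.24 log units; within the scatter), so neither group tried at this position has yet moved the number beyond the scatter.

No measurement is available to explain this result. As far as these compounds go, whether a carboxylic acid or a longer chain in place of benzyl on this amine nitrogen would also stay within the scatter remains open.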